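Three anilide variants and a fourth still unmeasured

The source may report more compounds than this note shows. Statements on the series, on what has been measured and on what is new or still open speak of the compounds shown alone.

Compound 1, `O=C(COc1ccc2cc(/C=C3/SC(=O)NC3=O)ccc2c1)Nc1ccc([N+](=O)[O-])cc1`, in an assay on isolated protein for inhibition of histone deacetylase 8 (Homo sapiens), with a stated time of 1 h (on this read-out lower numbers stand for stronger inhibition and higher numbers for weaker inhibition), gives 4000 nM.
Compound 2, `Cc1ccc(NC(=O)COc2ccc3cc(/C=C4/SC(=O)NC4=O)ccc3c2)cc1Cl`, in this assay gives > 50000 nM, a limit of the assay and not a number.
Compound 3, `O=C(COc1ccc2cc(/C=C3/SC(=O)NC3=O)ccc2c1)Nc1cc(Cl)cc(C(F)(F)F)c1`, in this assay gives > 50000 nM, likewise a limit and not a number.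

All three share one core and differ only in the aryl group attached to the amide-type nitrogen. Compound 3 stands at the limit of > 50000 nM in this assay, at which 2 of the 3 values shown sit, so its own value is a limit and not a number. Compound 4, `O=C(COc1ccc2cc(/C=C3/SC(=O)NC3=O)ccc2c1)Nc1ccc(Br)c(Br)c1`, is the next member of the set: 3,4-dibromophenyl in place of 3-chloro-5-(trifluoromethyl)phenyl on an amide-type nitrogen. Among the measured compounds shown here, two measured steps bear on this change, both starting from compound 1, the only compound with a real number: an at least 12-fold higher number from compound 1 to compound 2 (1.09 log units; beyond the scatter) and an at least 12-fold higher number from compound 1 to compound 3 (1.09 log units; beyond the scatter). In each case a chlorine-bearing aryl group entering in place of the nitrophenyl carried the value out to the limit. Between the two chlorinated members the data give a step that the two limits leave unreadable from compound 2 to compound 3. Since the change to compound 4 again places a halogen-bearing aryl group on the same nitrogen, the expected step is an at least 1.2-fold lower number from compound 3 to compound 4 (0.09 log units; that floor lies within the scatter), with no movement that can be told apart from a limit. Compound 4 is therefore estimated at 40000 nM, within a range from 5000 nM to 200000 nM, and a fair chance remains that only a limit is reported.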

Compound 4, half-maximal inhibitory concentration: > 50000 nM
Compound 4 ended at the assay's limit; the forecaster's own chance of this, stated with the estimate: 65%; at least 1.2-fold (0.09 log units) between middle value and limit.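

Among the compounds shown here, replacing the 4-nitrophenyl on the amide-type nitrogen with 3,4-dibromophenyl gives an at least 12-fold higher number from compound 1 to compound 4 (1.09 log units; beyond the scatter), and this is the first aryl group in the set that reaches the limit while carrying bromine and no chlorine. Across these four compounds, then, the drop from compound 1 does not depend on chlorine, or on the methyl or trifluoromethyl group that came with it, and compound 1 is the only member that goes against the pattern of ending at the limit. Compound 2, compound 3 and compound 4 cannot be ranked against one another, and the steps among them cannot be read, since each gives only a limit and not a number: the limit of > 50000 nM in this assay, at which 3 of the 4 values shown sit.

As far as these compounds go, with a single measured number in the set, it remains open whether the nitro group itself accounts for the measurable inhibition of compound 1 or whether other aryl groups on this nitrogen could match it. An aryl group bearing a nitrile, a carboxylic acid or an amine would test this, and a result that falls inside the measurable range would give this position a second real number to compare.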